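The compounds below may be only part of what the source reports. "The series", "measured", "known", "first", "only" and "open" are said of these compounds alone.

Measured so far: compound 1 `COc1cc(-c2nc(C(c3ccc(F)cc3)c3ccc(F)cc3)sc2CC(=O)O)ccn1` gives 60% in an in vitro functional assay on HEK285-7 cells for antagonist activity at prostaglandin D2 receptor 2 (Homo sapiens), read by BRET and beta-arrestin recruitment; on this read-out higher numbers stand for larger maximal responses and lower numbers for smaller maximal responses; compound 2 `O=C(O)Cc1sc(C(c2ccc(F)cc2)c2ccc(F)cc2)nc1-c1cc(F)nc(F)c1` gives 80%.

Compound 2 stands highest of the two numbers, with compound 1 the nearest, lower by a gap beyond the scatter. Compound 3 `O=C(O)Cc1sc(C(c2ccc(F)cc2)c2ccc(F)cc2)nc1-c1ccncc1` differs from compound 2 in one place: pyridin-4-yl in place of 2,6-difluoropyridin-4-yl on an aromatic carbon. Among the measured compounds shown here, only one measured step bears on this change, a number 20 percentage points higher from compound 1 to compound 2 (beyond the scatter), where the group was exchanged on the same aromatic carbon. Since compound 3 loses the fluorinated ring that accompanied that rise, compound 3 is expected to fall back modestly, a number 15 percentage points lower from compound 2 to compound 3 (beyond the scatter), toward the value of compound 1. Compound 3 is thus estimated at 65%, within 45% to 85%.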

Compound 3, largest response reached (reported as efficacy), in percent of the reference or control that the assay uses: 80%
Compound 3: middle estimate off by 15 percentage points, on the low side; the range from low to high includes it.
By their numbers in this assay, from the lowest: compound 1; then compounds 2 and 3 (each within the scatter of the next).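

In this assay, taking away both fluorines of the 2,6-difluoropyridin-4-yl group gives no change at the digits printed from compound 2 to compound 3 (within the scatter) and so shows that this position holds its response without them. Taking the methoxy off the ring of compound 1 gives a number 20 percentage points higher from compound 1 to compound 3 (beyond the scatter) and leaves compound 1 as the only one of the three with the lower number. No measurement shown here gives a reason for either step.

Going by these compounds, whether a methyl group, a chlorine atom or an amine in place of that methoxy would give a number like that of compound 1 or like that of compound 3 stays open. So does whether a phenyl ring could stand in for the pyridin-4-yl group.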